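The source may report more compounds than this note shows. Statements on the series, on what has been measured and on what is new or still open speak of the compounds shown alone.

Of the compounds shown here, three built on one shared core have been tested in a functional assay on MCF7 cells (Homo sapiens) for cytotoxicity, read by MTT assay, with a stated time of 24 h; on this read-out higher numbers stand for weaker inhibition and lower numbers for stronger inhibition. Compound 1 `FC(F)(F)Oc1ccc(-c2cc(COc3ccccc3-c3nc4ccccc4s3)on2)cc1` gives 26600 nM, compound 2 `COc1cc(-c2cc(COc3ccccc3-c3nc4ccccc4s3)on2)cc(OC)c1OC` gives 25600 nM, and compound 3 `COc1ccc(-c2cc(COc3ccccc3-c3nc4ccccc4s3)on2)cc1` gives 22100 nM. Compound 3 has the lowest of these three numbers, yet all three lie within the usual scatter of one another, so none can be called stronger or weaker. Among the compounds with values here, the only single change measured so far, a 1.2-fold lower number from compound 1 to compound 3 (0.08 log units; within the scatter), also swapped a small group at the same aromatic carbon and stayed within the scatter. Compound 4 `Cc1ccc(-c2cc(COc3ccccc3-c3nc4ccccc4s3)on2)cc1` differs from compound 3 by methyl in place of methoxy on an aromatic carbon. Within the data shown here, since the one comparable change was flat, the expected step of a 1.0-fold higher number from compound 3 to compound 4 (0.02 log units; within the scatter) in this assay is none beyond the scatter. Compound 4 is therefore estimated at 23000 nM, with a range from 11000 nM to 48000 nM.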

Compound 4, half-maximal inhibitory concentration: 27500 nM
Compound 4: the middle estimate sits 1.2-fold (0.08 log units) below what was measured; the range from low to high includes it.
By their numbers in this assay, from the lowest: compounds 3, 2, 1 and 4 (each within the scatter of the next).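

In this assay, swapping the methoxy for a methyl at this aromatic carbon, para to a large group, gives a 1.2-fold higher number from compound 3 to compound 4 (0.09 log units; within the scatter) and so shows no real difference. Methyl in place of trifluoromethoxy at the same carbon gives the same picture (a 1.0-fold higher number from compound 1 to compound 4 (0.01 log units; within the scatter)), so the oxygen-linked groups and the plain methyl cannot be told apart here. No measurement shown here offers an explanation for this flat result.

As far as these compounds go, whether an amine or a carboxylic acid at this carbon would move the number beyond the scatter remains open. From the compounds shown here alone, the effect of changes elsewhere on the shared core also remains open.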